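Amide aryl truncation: compound 3 to compound 4

The compounds below may be only part of what the source reports. "The series", "measured", "known", "first", "only" and "open" are said of these compounds alone.

Measured compounds:
compound 1 `O=C(Nc1cccc(-n2cc(-c3ccncc3)c(-c3ccc(Cl)c(O)c3)n2)c1)Nc1cccc(C(F)(F)F)c1` gives 1340 nM
compound 2 `COc1cc(-c2nn(-c3cccc(NC(=O)c4cccc(C(F)(F)F)c4)c3)cc2-c2ccncc2)ccc1Cl` gives 1570 nM
compound 3 `COc1cc(-c2nn(-c3cccc(NC(=O)c4ccc(Cl)c(C(F)(F)F)c4)c3)cc2-c2ccncc2)ccc1Cl` gives 1620 nM

In a functional assay on RPMI-8226 cells (Homo sapiens) for inhibition, read by sulforhodamine B assay, with a stated time of 48 h (on this read-out lower numbers stand for stronger inhibition and higher numbers for weaker inhibition), compound 3 gives 1620 nM, nominally the highest of the three numbers, yet compound 2 and compound 1 both lie within the scatter of it, so no order among the three can be read. Within the data shown here, the only single-point step available is a 1.0-fold higher number from compound 2 to compound 3 (0.01 log units; within the scatter), which shows that adding chloro on the amide aryl ring left the number unchanged beyond the scatter.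

Compound 4 `COc1cc(-c2nn(-c3cccc(NC(=O)c4ccccc4)c3)cc2-c2ccncc2)ccc1Cl` differs from compound 3 by phenyl in place of 4-chloro-3-(trifluoromethyl)phenyl on a carbonyl carbon. The step from compound 2 to compound 3 bears on the chloro part of this change and argues that its removal should cost nothing beyond the scatter. Among the measured compounds shown here, no measured step removes the trifluoromethyl from this position, so that part of the change is uncharted; the three measured compounds all carry a trifluoromethyl on the amide or urea aryl ring, and the narrow band they occupy gives no guide to its absence. A modest weakening is therefore expected, with wide uncertainty. Compound 4 is expected to give 2600 nM, in the range 1000 nM to 7000 nM. This estimate corresponds to the expected step of a 1.6-fold higher number from compound 3 to compound 4 (0.21 log units; within the scatter).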

Compound 4, half-maximal inhibitory concentration: 850 nM
Compound 4: the middle estimate sits 3.1-fold (0.49 log units) above what was measured, outside the stated range (below it).
By their numbers in this assay, from the lowest: compounds 4, 1, 2 and 3 (each within the scatter of the next).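

In this assay, replacing 4-chloro-3-(trifluoromethyl)phenyl with phenyl on the carbonyl carbon gives a 1.9-fold lower number from compound 3 to compound 4 (0.28 log units; within the scatter), so removing both substituents together leaves the number inside the band already seen for compounds that carry trifluoromethyl. Among these compounds, the single change of hydrogen in place of trifluoromethyl gives a 1.8-fold lower number from compound 2 to compound 4 (0.27 log units; within the scatter), which fills the gap left by the earlier compounds and shows that, at this position, the trifluoromethyl is not required to keep the number in that band, while compound 4 gives no reading of any gain from its removal. No evidence is available that bears on this outcome.

All four numbers lie in one narrow band, each within the scatter of the next, so the position has yet to show any change that separates two compounds in this assay. As far as these compounds go, whether an amine or a carboxylic acid on the phenyl, or a longer alkyl chain in place of the phenyl on the carbonyl carbon, would move the number beyond the scatter stays open, as does whether the same tolerance holds for the urea of compound 1.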